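Terminal-ring swap in a nitrile series: lipophilicity notes

The compounds below may be only part of what the source reports. "The series", "measured", "known", "first", "only" and "open" are said of these compounds alone.

Of the compounds shown here, two have been measured so far. Compound 1 `CCCCC(Nc1c(C#N)c(-c2ccc(-c3ccccc3OCC)cc2)nc2cnccc12)C(N)=O` gives 3.6 in a physicochemical assay for lipophilicity, read by HPLC, at pH 7.5; a lower number here means a more polar compound, a higher number a more lipophilic compound. Compound 2 `CC[C@@H](Nc1c(C#N)c(-c2ccc(-c3ccccc3CO)cc2)nc2cnccc12)C(N)=O` gives 2.1 in this assay, which is the lower of the two numbers; the gap to compound 1 lies beyond the usual scatter of repeated measurements. For the measured compounds named here, no two measured compounds differ in only one place, so no single step has been isolated.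

Compound 3 `CC[C@@H](Nc1c(C#N)c(-c2ccc(-c3cccc(C)c3)cc2)nc2cnccc12)C(N)=O` has not yet been measured. It differs from compound 2 in one place: 3-methylphenyl in place of 2-(hydroxymethyl)phenyl on an aromatic carbon. The group that leaves carries one hydrogen-bond donor and one hydrogen-bond acceptor; the group that enters carries none, and the heavy-atom count drops by one.

For this assay a step upward from compound 2 to compound 3 is expected, clearly beyond the scatter, on the order of a number 1.20 log units higher from compound 2 to compound 3 (beyond the scatter). Compound 3 is therefore estimated at 3.3, with a range from 2.8 to 3.8; the measurement will show whether it lands near compound 1 or short of it.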

Compound 3, distribution coefficient: 3
Beside the measured number, compound 3's estimate is 0.30 log units above it, and the stated range covers the measured number.
By their numbers in this assay, from the lowest: compound 2; then compound 3; then compound 1.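

In this assay the terminal ring gives its first isolated step: 3-methylphenyl in place of 2-(hydroxymethyl)phenyl, on an aromatic carbon para to a large group, gives a number 0.90 log units higher from compound 2 to compound 3 (beyond the scatter). The rest of the structure of compound 3 stays fixed, so this gap can be assigned to the terminal ring alone, but the swap still changes several things at once: the leaving group has 8 heavy atoms, 1 hydrogen-bond donor and 1 hydrogen-bond acceptor, the entering group of compound 3 has 7 heavy atoms and neither donor nor acceptor, and the substituent's name moves from 2- to 3- on that ring. No measurement available here assigns the step to any one of these differences.

The compounds shown leave open how much of the step follows the substituent itself and how much its site on the ring, a split that a pair such as 2-methylphenyl and 3-(hydroxymethyl)phenyl would address. On these data alone, how an aminomethyl group or a carboxylic acid on the same ring would read in this assay at this pH also remains open.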